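Shortening the hydroxyalkyl chain of a weak agonist

The source may report more compounds than this note shows. Statements on the series, on what has been measured and on what is new or still open speak of the compounds shown alone.

Compound 1 `CCC[C@@H](CCO)Nc1nc(N)nc(C)c1Cc1ccc(CNC2CN(C)C2)cc1OC` is known only by a limit in an assay on HEK293 cells for agonist activity at Toll-like receptor 8 (Homo sapiens); on this read-out higher numbers stand for an effect only at larger amounts of compound and lower numbers for an effect already at smaller amounts: in this assay compound 1 gives > 10000 nM, which is a limit of the assay and not a number (the limit of > 10000 nM in this assay, at which 1 of the 2 values shown sits). Compound 2 `CCC[C@@H](CCO)Nc1nc(N)nc(C)c1Cc1ccc(CNC)cc1OC` differs from it by methyl in place of 1-methylazetidin-3-yl on an amine nitrogen, and in this assay compound 2 gives 6460 nM. The step of an at least 1.5-fold lower number from compound 1 to compound 2 (0.18 log units; that floor lies within the scatter) is the only measured one, and it touches a different part of the molecule.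

Compound 3 `CCC[C@@H](CO)Nc1nc(N)nc(C)c1Cc1ccc(CNC2CN(C)C2)cc1OC` differs from compound 1 by hydroxy in place of hydroxymethyl on a saturated chain carbon, two bonds along the chain from a nitrogen on an aromatic ring. No measured step alters the hydroxyalkyl chain, so nothing among the shown values speaks for a large shift in either direction. The step from compound 1 to compound 3 is therefore expected to be a step that the limit leaves unreadable from compound 1 to compound 3 in this assay, within the scatter. For compound 3 the estimate in this assay is 15000 nM, with a range from 5000 nM to 50000 nM, and the result may again come out only as a limit.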

Compound 3, half-maximal effective concentration: 6170 nM
For compound 3 the middle estimate is 2.4-fold (0.39 log units) above the measured one; measured number inside the range.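

In this assay, among these compounds, this is the first measured change at the hydroxyalkyl chain: going from 2-hydroxyethyl to hydroxymethyl gives an at least 1.6-fold lower number from compound 1 to compound 3 (0.20 log units; that floor lies within the scatter). Compound 1 stands at a limit of the assay, so this step is a floor and not a true size: the limit of > 10000 nM in this assay, at which 1 of the 3 values shown sits. Compound 3 still carries the 1-methylazetidin-3-yl group on the amine nitrogen yet gives a number, so that group does not by itself hold a compound at the limit.

The compounds shown leave open how large the effect of shortening this chain really is, and whether it would add to the change from 1-methylazetidin-3-yl to methyl on the amine nitrogen. As far as these compounds go, what an amine, a methoxy group or a longer chain such as 3-hydroxypropyl would do at this carbon also stays open.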